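Amide substituent change on a core without measurable activity

The source may report more compounds than this note shows. Statements on the series, on what has been measured and on what is new or still open speak of the compounds shown alone.

Compound 1 `C=CCN(C)C(=O)c1ccc(C(CC)(CC)c2ccc(OCCC(O)(CC)CC)c(C)c2)n1CC` shows no measurable activity in a functional assay on HepG2 cells (Homo sapiens) for antiproliferative activity, read by MTT assay, with a stated time of 48 h; a lower number here means a stronger inhibitor, a higher number a weaker inhibitor. In this assay compound 1 gives > 50000 nM, which is a limit of the assay and not a number. Compound 2 `CCn1c(C(=O)Nc2cccc(C(F)(F)F)c2)ccc1C(CC)(CC)c1ccc(OCCC(O)(CC)CC)c(C)c1` carries (3-(trifluoromethyl)phenyl)amino in place of allyl(methyl)amino on a carbonyl carbon. In this assay compound 2 gives > 50000 nM, again a limit rather than a number. The step that the two limits leave unreadable from compound 1 to compound 2 is therefore unreadable, since both values sit at the limit of > 50000 nM in this assay, at which 2 of the 2 values shown sit. Compound 1 thus stands at the limit, and the measured pair separates nothing.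

Compound 3 `CCn1c(C(=O)N(C)CCO)ccc1C(CC)(CC)c1ccc(OCCC(O)(CC)CC)c(C)c1` awaits measurement in this assay. It differs from compound 1 by hydroxymethyl in place of vinyl on a saturated chain carbon bound to an amide-type nitrogen. Among the compounds with values here, no measured step bears on this change: the only one, a step that the two limits leave unreadable from compound 1 to compound 2, leaves its size unreadable because both ends rest at the limit of > 50000 nM in this assay, at which 2 of the 2 values shown sit. With both measured compounds at the limit, the expectation is that compound 3 also stays at or near it. Compound 3 is estimated at 60000 nM in this assay, within a range from 15000 nM to 200000 nM. The expected step that the limit leaves unreadable from compound 1 to compound 3 is accordingly none that the scatter would reveal, and a further limit is the likely outcome.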

Compound 3, half-maximal inhibitory concentration: 510 nM
The estimate for compound 3 lay 120-fold (2.07 log units) above the measured number; the whole stated range lies above it.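

The amide substituent is a place on the shared core where the read-out in this assay can move, which the earlier pair, both resting at a limit, could not show. Hydroxymethyl in place of vinyl on a saturated chain carbon bound to an amide-type nitrogen, with 2 heavy atoms in each group, gives an at least 98-fold lower number from compound 1 to compound 3 (1.99 log units; beyond the scatter) and brings in 1 hydrogen-bond donor and 1 hydrogen-bond acceptor, while (2-hydroxyethyl)(methyl)amino in place of (3-(trifluoromethyl)phenyl)amino on a carbonyl carbon gives an at least 98-fold lower number from compound 2 to compound 3 (1.99 log units; beyond the scatter) in the same assay. Both sizes are lower bounds and not exact steps, since compound 1 and compound 2 each give a limit and not a number: the limit of > 50000 nM in this assay, at which 2 of the 3 values shown sit.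

Within the data shown here, with compound 3 the only compound here that gives a number, the data cannot say whether the hydroxyl or the rest of the 2-hydroxyethyl chain accounts for the gain. A methoxyethyl group, a 3-hydroxypropyl chain, a 2-aminoethyl group or a carboxymethyl group in place of 2-hydroxyethyl would bear on this, and would show how narrow the requirement at this amide is.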